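Extending the sulfur substituent in a benzimidazole series

A few compounds are considered here, and "the series" means these few. Any claim that something is new, unique, unknown or untested is made for them only; others in the source may bear on it.

Measured compounds:
compound 1, `CSc1nc2ccccc2n1C1CCN(CCCC(=O)c2ccc(F)cc2)CC1`, 0.68 mg/kg
compound 2, `O=C(CCCSc1nc2ccccc2n1C1CCN(CCCC(=O)c2ccc(F)cc2)CC1)c1ccc(F)cc1`, > 3 mg/kg

Within the data shown here, in a functional assay on the whole organism (strain STD-ddY) with Mus musculus as the target, with stated times of 1 h and 24 h (on this read-out higher numbers stand for an effect only at larger amounts of compound and lower numbers for an effect already at smaller amounts), compound 1 gives 0.68 mg/kg, the only plain number in the set. The one other result is not a plain number. Among the measured compounds shown here, compound 2 reaches only a limit of this assay, > 3 mg/kg, and the step of an at least 4.4-fold higher number from compound 1 to compound 2 (0.64 log units; beyond the scatter) is the sole measured change available. That step adds a carbonyl-bearing chain at the carbon bound to the sulfur, and the limit of > 3 mg/kg in this assay, at which 1 of the 2 values shown sits, is where compound 2 sits.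

Compound 3, `O=C(CCCN1CCC(n2c(SCC(=O)c3ccc(Cl)cc3)nc3ccccc32)CC1)c1ccc(F)cc1`, has not been measured. It differs from compound 1 by (4-chlorophenyl)carbonyl in place of hydrogen on a saturated chain carbon bound to a sulfur, the same site as in the step to compound 2 but with a shorter link and a chlorine in place of the fluorine on the ring. For the measured compounds named here, the one relevant step ran toward a higher number and beyond the scatter, so a higher number is expected for compound 3 as well. The expected step is a 4.4-fold higher number from compound 1 to compound 3 (0.64 log units; beyond the scatter). Compound 3 is estimated at 3 mg/kg, within a range of 1.2 mg/kg to 8 mg/kg, with a fair chance that only a limit is reported.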

Compound 3, dose for half-maximal effect: 1.6 mg/kg
Beside the measured number, compound 3's estimate is 1.9-fold (0.27 log units) above it; low and high end bracket the measured number.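

With compound 3, the site on the saturated chain carbon bound to a sulfur gives a second reading, and this time a plain number: in this assay, (4-chlorophenyl)carbonyl in place of hydrogen brings a 2.4-fold higher number from compound 1 to compound 3 (0.37 log units; beyond the scatter). The direction of the earlier step therefore holds for both substituted compounds, while the size of the change can now be read for one of them, and it is modest. The comparison between the two substituted compounds, an at least 1.8-fold lower number from compound 2 to compound 3 (0.27 log units; that floor lies within the scatter), does not separate them, and compound 2 remains a limit of the assay: the limit of > 3 mg/kg in this assay, at which 1 of the 3 values shown sits.

Compound 2 and compound 3 differ in both the length of the link and the halogen on the ring, so the shares of these two changes cannot be told apart here. On these data alone, what an amine, a carboxylic acid or a plain ethyl at this carbon would do to the number remains open, as does whether a link longer than that in compound 2 would continue the same direction.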